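The compounds below may be only part of what the source reports. "The series", "measured", "known", "first", "only" and "open" are said of these compounds alone.

Compound 3 `C=CC(=O)Nc1cc2c(Nc3ccc(OCc4cccc(F)c4)c(Cl)c3)ncnc2cc1OCc1cn(CCC(=O)NO)nn1` gives 24800 nM in a functional assay on SK-BR-3 cells (Homo sapiens) for antiproliferative activity, read by MTT assay, with a stated time of 72 h; on this read-out higher numbers stand for weaker inhibition and lower numbers for stronger inhibition. Compound 1 `C=CC(=O)Nc1cc2c(Nc3ccc(OCc4cccc(F)c4)c(Cl)c3)ncnc2cc1OCc1cn(CCCC(=O)NO)nn1` carries the change (hydroxycarbamoyl)methyl in place of hydroxycarbamoyl on a saturated chain carbon, two bonds along the chain from an aromatic nitrogen and gives 20200 nM in this assay, and the step of a 1.2-fold lower number from compound 3 to compound 1 (0.09 log units; within the scatter) is small. Compound 2 `C=CC(=O)Nc1cc2c(Nc3ccc(F)c(Cl)c3)ncnc2cc1OCc1cn(CCCC(=O)NO)nn1` gives 30800 nM in this assay, and the step of a 1.5-fold higher number from compound 1 to compound 2 (0.18 log units; within the scatter) is also small; the difference between the cores of compound 2 and compound 3 is not broken down here. Compound 4 `C=CC(=O)Nc1cc2c(Nc3ccc(F)c(Cl)c3)ncnc2cc1OCc1cn(CCCCC(=O)NO)nn1`, not yet measured, differs from compound 2 by (hydroxycarbamoyl)methyl in place of hydroxycarbamoyl on a saturated chain carbon, three bonds along the chain from an aromatic nitrogen, the same kind of change as before, though here the place is three bonds along the chain from an aromatic nitrogen rather than two. The step is expected to be a 1.2-fold lower number from compound 2 to compound 4 (0.07 log units; within the scatter), resting on the earlier step of a 1.2-fold lower number from compound 3 to compound 1 (0.09 log units; within the scatter) between compound 3 and compound 1. Compound 4 is therefore estimated at 26000 nM in this assay, between 11000 nM and 65000 nM.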

Compound 4, half-maximal inhibitory concentration: 20000 nM
For compound 4 the middle estimate is 1.3-fold (0.11 log units) above the measured one; low and high end bracket the measured number.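

The change from 3-(hydroxycarbamoyl)propyl to 4-(hydroxycarbamoyl)butyl gives a 1.5-fold lower number from compound 2 to compound 4 (0.19 log units; within the scatter) in this assay. Set beside the matching change one chain position shorter on the other core, the result does not depend on the core as far as these numbers can tell: the same change on two cores in this assay, a 1.2-fold lower number (0.09 log units; within the scatter) from compound 3 to compound 1 and a 1.5-fold lower number (0.19 log units; within the scatter) from compound 2 to compound 4, 1.3-fold (0.10 log units) apart, within the scatter of two such steps

Both steps lie within the scatter, so neither shows that chain length matters here, and two pairs of compounds give no general rule for the series.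

The compounds shown leave open whether a still longer chain, such as 5-(hydroxycarbamoyl)pentyl, would lie beyond the scatter. They also leave open what a carboxylic acid in place of the hydroxycarbamoyl group would give.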